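A few compounds are considered here, and "the series" means these few. Any claim that something is new, unique, unknown or untested is made for them only; others in the source may bear on it.

Three compounds share one core and differ only in the aryl group that sits on the pyridine of that core. Compound 1 `CC(C(=O)NCc1ccc(C(F)(F)F)nc1-c1ccc(Cl)cc1)c1ccc(NS(C)(=O)=O)c(F)c1` gives 0.7 nM in an assay on CHO cells for antagonist activity at transient receptor potential cation channel subfamily V member 1 (Homo sapiens), read by FLIPR; on this read-out higher numbers stand for weaker inhibition and lower numbers for stronger inhibition. Compound 2 `CC(C(=O)NCc1ccc(C(F)(F)F)nc1-c1cccc(Cl)c1)c1ccc(NS(C)(=O)=O)c(F)c1` gives 0.5 nM in this assay. Compound 3 `Cc1cc(-c2nc(C(F)(F)F)ccc2CNC(=O)C(C)c2ccc(NS(C)(=O)=O)c(F)c2)ccc1F` gives 0.4 nM in this assay, the lowest of the three numbers, though its gaps to the others, a 1.8-fold lower number from compound 1 to compound 3 (0.24 log units; within the scatter) and a 1.3-fold lower number from compound 2 to compound 3 (0.10 log units; within the scatter), both sit within the scatter, as does a 1.4-fold lower number from compound 1 to compound 2 (0.15 log units; within the scatter). Compound 4 `COc1ccc(-c2nc(C(F)(F)F)ccc2CNC(=O)C(C)c2ccc(NS(C)(=O)=O)c(F)c2)cc1F` carries the next change at this same position: 3-fluoro-4-methoxyphenyl in place of 4-fluoro-3-methylphenyl on an aromatic carbon. Since every swap of this aryl group so far moved the number by no more than the scatter, no step beyond the scatter is expected here either; the expected step is a 1.3-fold higher number from compound 3 to compound 4 (0.10 log units; within the scatter). Compound 4 is thus estimated at about 0.5 nM, between 0.2 nM and 1.3 nM.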

Compound 4, inhibition constant: 4.2 nM
Compound 4: middle estimate off by 8.4-fold (0.92 log units), on the low side; the whole stated range lies below it.
By their numbers in this assay, from the lowest: compounds 3, 2 and 1 (each within the scatter of the next); then compound 4.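

In this assay this position proves less tolerant than the earlier swaps suggested: the steps are an 11-fold higher number from compound 3 to compound 4 (1.02 log units; beyond the scatter) and an 8.4-fold higher number from compound 2 to compound 4 (0.92 log units; beyond the scatter) and a 6.0-fold higher number from compound 1 to compound 4 (0.78 log units; beyond the scatter) and all lie beyond the scatter. So 3-fluoro-4-methoxyphenyl is the first aryl group here to stand apart from the others, and it is also the one that brings an oxygen. No measurement shown gives a reason for this step.

Compound 4 changes both the substituents and their arrangement relative to compound 3, so the shown data cannot separate these two changes. As far as these compounds go, how an ethoxy group or an amine in place of the methoxy would behave also remains open.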